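The compounds below may be only part of what the source reports. "The series", "measured", "known", "first", "only" and "open" are said of these compounds alone.

Going by the values given here, compound 3 `O=C(Nc1ccc(Oc2ccnc3[nH]ccc23)c(F)c1)c1cc(-c2ccc(C(F)(F)F)cc2)ccn1` stands highest of the three numbers measured so far: in a functional assay on A549 cells (Homo sapiens) for cytotoxicity, read by MTT assay, with a stated time of 72 h (a higher number here means a weaker inhibitor, a lower number a stronger inhibitor), compound 3 gives 4920 nM. Compound 1 `Cc1cccc(-c2ccnc(C(=O)Nc3ccc(Oc4ccnc5[nH]ccc45)c(F)c3)c2)c1` gives 1750 nM in this assay, and compound 2 `COc1ccc(-c2ccnc(C(=O)Nc3ccc(Oc4ccnc5[nH]ccc45)c(F)c3)c2)cc1` gives 1040 nM. The steps of a 2.8-fold higher number from compound 1 to compound 3 (0.45 log units; beyond the scatter) and a 4.7-fold higher number from compound 2 to compound 3 (0.67 log units; beyond the scatter) both go upward, whereas a 1.7-fold lower number from compound 1 to compound 2 (0.23 log units; within the scatter). Compound 4 `O=C(Nc1ccc(Oc2ccnc3[nH]ccc23)c(F)c1)c1cc(-c2ccc(F)cc2F)ccn1` differs from compound 3 in one place: 2,4-difluorophenyl in place of 4-(trifluoromethyl)phenyl on an aromatic carbon. The two steps into compound 3 are the ones that bear on this change: each swaps the group on the same aromatic carbon, and each moved the number by a modest amount. On that basis a downward step is expected, a 2.5-fold lower number from compound 3 to compound 4 (0.39 log units; beyond the scatter). Compound 4 is therefore estimated at 2000 nM, within a range from 800 nM to 5000 nM.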

Compound 4, half-maximal inhibitory concentration: > 10000 nM
Compound 4 gave a limit, no number; the forecaster's own chance of this, stated with the estimate: 2%; at least 5.0-fold (0.69 log units) between middle value and limit.
By their numbers in this assay, from the lowest: compounds 2 and 1 (each within the scatter of the next); then compound 3. At a limit, above all of these: compound 4.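

In this assay compound 4 gives a limit of the assay, not a number: the limit of > 10000 nM in this assay, at which 1 of the 4 values shown sits. At this aromatic carbon, opposite the ring nitrogen, the 2,4-difluorophenyl group gives an at least 9.6-fold higher number from compound 2 to compound 4 (0.98 log units; beyond the scatter) and an at least 5.7-fold higher number from compound 1 to compound 4 (0.75 log units; beyond the scatter), so both fluorine-bearing aryl groups, in compound 3 and compound 4, now sit beyond the scatter above the 4-methoxyphenyl and 3-methylphenyl groups. Against 4-(trifluoromethyl)phenyl the result is only an at least 2.0-fold higher number from compound 3 to compound 4 (0.30 log units; that floor lies within the scatter), which leaves the order of those two unsettled.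

The compounds shown leave open how a plain phenyl, a 4-fluorophenyl or an amine would read at this carbon.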